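A bromophenyl group on an inactive series

The source may hold more compounds than are shown below. What is called first, only, known or untested is meant among the compounds shown, and "the series" means these compounds.

Measured in a functional assay on MGC-803 cells (Homo sapiens) for cytotoxicity, read by MTT assay, with a stated time of 72 h; on this read-out lower numbers stand for stronger inhibition and higher numbers for weaker inhibition:
Compound 1 `Cc1cc(NC(C)C)nc(SCc2nc3ccccc3[nH]2)n1`: > 100000 nM
Compound 2 `Cc1cc(N2CCCCC2)nc(SCc2nc3ccccc3[nH]2)n1`: > 100000 nM
Compound 3 `Cc1cc(N2CCNCC2)nc(SCc2nc3ccccc3[nH]2)n1`: > 100000 nM

Compound 2 gives > 100000 nM, which is a limit and not a number. The same holds for the whole set: the limit of > 100000 nM in this assay, at which 3 of the 3 values shown sit.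

Compound 4 `Cc1cc(Nc2ccc(Br)cc2)nc(SCc2nc3ccccc3[nH]2)n1` carries (4-bromophenyl)amino in place of piperidin-1-yl on an aromatic carbon.

The measured steps that bear on this change are a step that the two limits leave unreadable from compound 1 to compound 2 and a step that the two limits leave unreadable from compound 2 to compound 3. Neither has a readable size, and neither involves the (4-bromophenyl)amino group, so they set no scale. Only a modest gain in this assay is expected, and a result at the limit remains quite possible. The expected step is an at least 3.3-fold lower number from compound 2 to compound 4 (0.52 log units; beyond the scatter). For compound 4 the estimate is 30000 nM, with an estimated range of 5000 nM to 100000 nM.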

Compound 4, half-maximal inhibitory concentration: 26800 nM
The estimate for compound 4 lay 1.1-fold (0.05 log units) above the measured number; the measured number falls inside the stated range.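

In this assay, compound 4 is the only compound shown with a readable number, so (4-bromophenyl)amino on this aromatic carbon moves the series off its limit: the limit of > 100000 nM in this assay, at which 3 of the 4 values shown sit. The change gives an at least 3.7-fold lower number from compound 2 to compound 4 (0.57 log units; beyond the scatter), and likewise an at least 3.7-fold lower number from compound 3 to compound 4 (0.57 log units; beyond the scatter) and an at least 3.7-fold lower number from compound 1 to compound 4 (0.57 log units; beyond the scatter). Each of these steps starts from a limit and so gives only a minimum size, while the steps among compound 1, compound 2 and compound 3 cannot be read.

The compounds shown leave open whether this gain belongs to the aromatic ring or to the bromine. A plain phenylamino or a 4-chlorophenylamino group at this place would separate the two.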